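The compounds below may be only part of what the source reports. "The series", "measured", "known", "first", "only" and "open" are said of these compounds alone.

The compounds measured so far:

Compound 1, `O=C(COc1cccc2ccccc12)N/N=C/c1cccc([N+](=O)[O-])c1`. In an ADME assay on HEL cells (Homo sapiens) for cytotoxicity (a higher number here means that more compound is tolerated, a lower number that less compound is tolerated), compound 1 gives >= 20 ug/mL, which is a limit of the assay and not a number.

Compound 2, `C/C(=N\NC(=O)COc1cccc2ccccc12)c1ccc(O)cc1O`. In this assay compound 2 gives > 100 ug/mL, again a limit.

Compound 3, `C/C(=N\NC(=O)COc1cccc2ccccc12)c1ccc(Cl)cc1`. In this assay compound 3 gives >= 4 ug/mL, also a limit.

Within the data shown here, compound 3 therefore stands only at a limit, and the two other values shown are limits as well, so no compound here has a plain number. Among the measured compounds shown here, the one step between measured compounds that differ in a single place, a step that the two limits leave unreadable from compound 2 to compound 3, has a size that the two limits leave unreadable.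

The unmeasured compound 4, `C/C(=N\NC(=O)COc1cccc2ccccc12)c1ccc(Br)cc1`, differs from compound 3 by bromo in place of chloro on an aromatic carbon.

No measured step touches this kind of exchange, and the only step shown cannot be read in size, so there is nothing to argue for a step in either direction beyond the scatter. The estimate for compound 4 is therefore a value close to that of compound 3, 4 ug/mL, between 2 ug/mL and 10 ug/mL, and the expected step of a number no higher from compound 3 to compound 4 (the limit leaves the size open) is one within the scatter; the assay may again report only a limit.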

Compound 4, minimum cytotoxic concentration: 20 ug/mL
For compound 4 the middle estimate is 5.0-fold (0.70 log units) below the measured one, and the stated range ends below it.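

In this assay, among these compounds, compound 4 gives 20 ug/mL, the first plain number in this set rather than a limit, so a 4-bromophenyl group on the carbon with a double bond to nitrogen now has a measured level of tolerated compound. It also gives the first readable size for an exchange at this place: putting 4-bromophenyl where 2,4-dihydroxyphenyl stood gives an at least 5.0-fold lower number from compound 2 to compound 4 (0.69 log units; beyond the scatter), a step beyond the usual scatter that still has a limit at one end, so its true size may be larger. The other steps at this place, including bromo in place of chloro, cannot be read, because compound 3 has no plain number: the limit of >= 4 ug/mL in this assay, at which 1 of the 4 values shown sits.

From the compounds shown here alone, whether bromo and chloro on this aromatic carbon truly differ therefore stays open, and a plain number for the chloro compound would be needed to settle it. The compounds shown also leave open how a 4-hydroxyphenyl group with its single hydroxyl, or an amine or a carboxylic acid on the same aromatic carbon, would compare with bromo in this assay.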